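The source may hold more compounds than are shown below. What is called first, only, known or untested is meant among the compounds shown, and "the series" means these compounds.

Compound 1 `Nc1n[nH]c2cccc(-c3cccc(NC(=O)Nc4cccc(Cl)c4)c3)c12`: 1720 nM in a functional assay on A549 cells (Homo sapiens) for inhibition, read by MTT assay, with a stated time of 48 h; a lower number here means a stronger inhibitor, a higher number a weaker inhibitor.
Compound 3 `Nc1n[nH]c2cccc(-c3cccc(NC(=O)Nc4ccccc4F)c3)c12`: 1170 nM.
Compound 2 `Nc1n[nH]c2cccc(-c3cccc(NC(=O)Nc4ccc(Cl)cc4Cl)c3)c12` gives only a limit here, > 500000 nM.

Compound 3 has the lowest of the two numbers, with compound 1 nearest; the step of a 1.5-fold lower number from compound 1 to compound 3 (0.17 log units; within the scatter) stays within the scatter, so the two are indistinguishable. Compound 4 `COc1cccc(NC(=O)Nc2cccc(-c3cccc4[nH]nc(N)c34)c2)c1` differs from compound 3 in one place: 3-methoxyphenyl in place of 2-fluorophenyl on an amide-type nitrogen. Within the data shown here, two measured steps bear on this kind of swap. The step of an at least 420-fold lower number from compound 2 to compound 3 (2.63 log units; beyond the scatter) was large, but compound 2 sits at a limit (the limit of > 500000 nM in this assay, at which 1 of the 3 values shown sits), so its size is only a bound. The step of a 1.5-fold lower number from compound 1 to compound 3 (0.17 log units; within the scatter), a swap of one substituted phenyl for another, was small. Another such swap is therefore expected to give no step beyond the scatter, a 1.3-fold higher number from compound 3 to compound 4 (0.11 log units; within the scatter). Compound 4 is estimated at 1500 nM, expected between 500 nM and 5000 nM.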

Compound 4, half-maximal inhibitory concentration: 2490 nM
The estimate for compound 4 lay 1.7-fold (0.22 log units) below the measured number; the measured number falls inside the stated range.
By their numbers in this assay, from the lowest: compounds 3, 1 and 4 (each within the scatter of the next, the first and the last beyond it). At a limit, above all of these: compound 2.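

Swapping in 3-methoxyphenyl on the amide-type nitrogen gives the first modest step from the 2-fluorophenyl compound in this assay: a 2.1-fold higher number from compound 3 to compound 4 (0.33 log units; beyond the scatter). Methoxy in place of chloro on an aromatic carbon, however, leaves the number within the scatter, a 1.4-fold higher number from compound 1 to compound 4 (0.16 log units; within the scatter), so compounds 1 and 4 cannot be told apart. The remaining step, an at least 200-fold lower number from compound 2 to compound 4 (2.30 log units; beyond the scatter), is only a bound, set by a limit: the limit of > 500000 nM in this assay, at which 1 of the 4 values shown sits.

From the compounds shown here alone, what a phenyl carrying an amine or a carboxylic acid in place of methoxy would give stays open. Also open, going by these compounds, is which of the two chloro groups of compound 2 goes with its limit.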